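Compound 3 to compound 4: ethyl to benzyl

The source may report more compounds than this note shows. Statements on the series, on what has been measured and on what is new or still open speak of the compounds shown alone.

Measured in a functional assay on KB cells (Homo sapiens) for cytotoxicity (on this read-out higher numbers stand for an effect only at larger amounts of compound and lower numbers for an effect already at smaller amounts), so far
- compound 1 `Nc1nc(N)c2nc(CNc3ccc(C(=O)NCCCC(=O)O)cc3)cnc2n1` gives > 100 ug/mL as a limit
- compound 2 `CN(CCCCC(=O)N[C@@H](CCC(=O)O)C(=O)O)Cc1cnc2nc(N)nc(N)c2n1` gives > 100 ug/mL as a limit
- compound 3 `CCN(Cc1cnc2nc(N)nc(N)c2n1)c1ccc(C(=O)N[C@@H](CCC(=O)O)C(=O)O)cc1` gives 0.005 ug/mL as the only number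

Within the data shown here, compound 3 is therefore the sole numerical anchor, and no measured pair differs in one place. Compound 4 `Nc1nc(N)c2nc(CN(Cc3ccccc3)c3ccc(C(=O)N[C@@H](CCC(=O)O)C(=O)O)cc3)cnc2n1` is not yet measured. It departs from compound 3 by phenyl in place of methyl on a saturated chain carbon bound to a nitrogen on an aromatic ring in a single change, phenyl in place of methyl on a saturated chain carbon bound to a nitrogen on an aromatic ring. Among the measured compounds shown here, with no measured step as a guide, a moderate loss of potency in this assay is expected, beyond the scatter and towards higher numbers. The expected change is a 10-fold higher number from compound 3 to compound 4 (1.00 log units; beyond the scatter) in this estimate. Compound 4 is estimated at 0.05 ug/mL within an expected range of 0.006 ug/mL to 0.5 ug/mL for now.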

Compound 4, concentration for half-maximal effect: > 100 ug/mL
Compound 4 gave a limit, no number; the forecaster's own chance of this, stated with the estimate: 3%; middle value at least 2000-fold (3.30 log units) from the limit.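

In this assay, among these compounds, phenyl in place of methyl on a saturated chain carbon bound to a nitrogen on an aromatic ring gives the first readable step: an at least 20000-fold higher number from compound 3 to compound 4 (4.30 log units; beyond the scatter). Compound 4 gives > 100 ug/mL, which is a limit and not a number. The step is therefore a floor, and its full size cannot be read: the limit of > 100 ug/mL in this assay, at which 3 of the 4 values shown sit.

The compounds shown leave open whether the added chain length or the aromatic ring accounts for the step. A propyl or a cyclohexylmethyl group in the same place would separate the two.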